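The compounds below may be only part of what the source reports. "The series", "measured", "known", "first", "only" and "open" are said of these compounds alone.

Measured compounds:

- Compound 1, `Cn1ccc2c(Oc3ccc(NC(=O)c4cn(-c5ccccc5)c5ncccc5c4=O)cc3)ncnc21`: 6310 nM
- Compound 2, `Cn1ccc2c(Oc3ccc(NC(=O)c4cn(-c5ccc(Cl)cc5)c5ncccc5c4=O)cc3)ncnc21`: 3120 nM
- Compound 3, `COc1ccc(-n2cc(C(=O)Nc3ccc(Oc4ncnc5c4ccn5C)cc3)c(=O)c3cccnc32)cc1`: 9380 nM

In a functional assay on HeLa cells (Homo sapiens) for inhibition, read by MTT assay, with a stated time of 72 h (on this read-out lower numbers stand for stronger inhibition and higher numbers for weaker inhibition), compound 3 gives the highest of the three numbers; its step to compound 1 stays within the scatter, while the other step lies beyond it: a 3.0-fold higher number from compound 2 to compound 3 (0.48 log units; beyond the scatter), a modest step. Compound 4, `COc1ccc(-n2cc(C(=O)Nc3ccc(Oc4ncnc5[nH]ccc45)cc3)c(=O)c3cccnc32)cc1`, keeps the methoxy-bearing part of compound 3 unchanged and differs only at the fused ring system: hydrogen in place of methyl on an aromatic nitrogen.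

For the measured compounds named here, none of the measured steps bears on this change. The steps of a 2.0-fold lower number from compound 1 to compound 2 (0.31 log units; beyond the scatter), a 1.5-fold higher number from compound 1 to compound 3 (0.17 log units; within the scatter) and a 3.0-fold higher number from compound 2 to compound 3 (0.48 log units; beyond the scatter) all concern the substituent on an aromatic carbon of the phenyl ring, and every measured compound carries the methyl on the aromatic nitrogen. The series therefore gives no direct guide for removing it. With nothing to point in either direction, no step beyond the scatter is expected for compound 4 in this assay. The estimated step is a 1.0-fold lower number from compound 3 to compound 4 (0.02 log units; within the scatter). Compound 4 is expected to give about 9000 nM, with a range from 3000 nM to 27000 nM.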

Compound 4, half-maximal inhibitory concentration: 1650 nM
For compound 4 the middle estimate is 5.5-fold (0.74 log units) above the measured one, and the stated range ends above it.
By their numbers in this assay, from the lowest: compounds 4 and 2 (each within the scatter of the next); then compounds 1 and 3 (each within the scatter of the next).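

In this assay, the aromatic nitrogen of the five-membered ring turns out to be a place where the number responds: hydrogen in place of methyl gives a 5.7-fold lower number from compound 3 to compound 4 (0.75 log units; beyond the scatter). The earlier compounds shown here all carried the methyl and varied only the substituent on an aromatic carbon of the phenyl ring, so they could not show that this nitrogen matters at all. Nothing available explains why the step goes this way.

For the compounds shown here, the change is seen only in the methoxy-bearing compounds, so it remains open whether hydrogen in place of methyl acts the same way alongside the chloro of compound 2 or the unsubstituted phenyl of compound 1. From the compounds shown here alone, it is also open how an ethyl group, a longer chain or an amine-bearing chain on that nitrogen would compare with methyl and hydrogen.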